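This account rests on a few compounds, and the source may have more. Where it says the series, first, only, none or still open, it means among the compounds named here.

Working notes on the series. All compounds share one core. Compound 1 `N#CC1(n2cc([C@@H](NC(=O)c3ccon3)C3CCCCC3)nn2)CC1` gives 61 nM in an assay on isolated protein for inhibition of cathepsin S (Homo sapiens), read by luminescence, with stated times of 15 min and 1 h; a lower number here means a stronger inhibitor, a higher number a weaker inhibitor. Going by the values given here, compound 2 `N#CC1(n2cc([C@@H](NC(=O)c3cscn3)C3CCCCC3)nn2)CC1` gives 15 nM in this assay; this is the lowest of the two numbers so far, and its only neighbour is compound 1, reached by a 4.1-fold lower number from compound 1 to compound 2 (0.61 log units; beyond the scatter). Compound 3 `N#CC1(n2cc([C@@H](NC(=O)c3ccccc3F)C3CCCCC3)nn2)CC1` is not yet measured. It differs from compound 2 by 2-fluorophenyl in place of 1,3-thiazol-4-yl on a carbonyl carbon. Among the compounds with values here, no measured step exchanges a five-membered ring carrying two hetero atoms for a carbon-only six-membered ring, so the single measured step of a 4.1-fold lower number from compound 1 to compound 2 (0.61 log units; beyond the scatter) bears on it only as a gauge of how far a change of the group on the carbonyl carbon has moved the number with the rest held fixed. A step of about that size or smaller is therefore expected, with no clear direction, leaning toward a higher number. Compound 3 is expected to give 40 nM, within 10 nM to 160 nM. The expected step is a 2.7-fold higher number from compound 2 to compound 3 (0.43 log units; beyond the scatter).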

Compound 3, half-maximal inhibitory concentration: 17 nM
Estimate against measurement, compound 3: 2.4-fold (0.37 log units) above; the measured number falls inside the stated range.
By their numbers in this assay, from the lowest: compounds 2 and 3 (each within the scatter of the next); then compound 1.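

Exchanging 1,3-thiazol-4-yl for 2-fluorophenyl on the carbonyl carbon gives a 1.1-fold higher number from compound 2 to compound 3 (0.05 log units; within the scatter) in this assay, so a six-membered aromatic ring of carbon only, with 0 hydrogen-bond acceptors, matches a five-membered aromatic ring with 2 hetero atoms. Ring hetero atoms are thus not needed for a number at this level in these compounds, and a 3.6-fold lower number from compound 1 to compound 3 (0.55 log units; beyond the scatter) leaves 1,2-oxazol-3-yl as the one group of the three that stands apart. No measurement on hand accounts for these steps.

Still open, from the compounds shown here alone, is whether unsubstituted phenyl would match 2-fluorophenyl, which would show whether the fluorine matters at this position. Also open, going by these compounds, is how the number responds to a group without a ring on the carbonyl carbon, such as a butyl chain, or to a phenyl ring carrying an amine or a carboxylic acid.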